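The compounds below may be only part of what the source reports. "The series", "measured", "known", "first", "only" and "open" are said of these compounds alone.

Measured compounds:
- compound 1 `CCOC(=O)c1c(-c2c(Cl)c3ccccc3oc2=O)nn(-c2ccc(OC)cc2)c1C(=O)OCC`: 27000 nM
- compound 2 `CCOC(=O)c1c(-c2cc3ccccc3oc2=O)nn(-c2cccc(C)c2)c1C(=O)OCC`: 245000 nM
- compound 3 `CCOC(=O)c1c(-c2cc3ccccc3oc2=O)nn(-c2ccc(OC)cc2)c1C(=O)OCC`: 90000 nM

All three were run in a functional assay on HeLa cells (Homo sapiens) for cytotoxicity, read by MTT assay, with a stated time of 48 h; a lower number here means a stronger inhibitor, a higher number a weaker inhibitor. Within this set compound 3 stands second highest of the three numbers; its nearest neighbour is compound 2, as the step of a 2.7-fold lower number from compound 2 to compound 3 (0.43 log units; beyond the scatter) shows, and its furthest is compound 1, where the step of a 3.3-fold higher number from compound 1 to compound 3 (0.52 log units; beyond the scatter) changed the chloro on the coumarin part of the shared core to hydrogen.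

The next compound, compound 4 `CCOC(=O)c1c(-c2cc3ccccc3oc2=O)nn(-c2ccc(Br)cc2)c1C(=O)OCC`, differs from compound 3 in one place: bromo in place of methoxy on an aromatic carbon. Going by the values given here, no measured step covers bromo in place of methoxy. Among the compounds with values here, the only step that varies the aryl on the pyrazole nitrogen is a 2.7-fold lower number from compound 2 to compound 3 (0.43 log units; beyond the scatter), a modest change for a different swap on that ring; the chloro step a 3.3-fold higher number from compound 1 to compound 3 (0.52 log units; beyond the scatter) sits elsewhere on the core and does not bear directly. Within the data shown here, with no direct precedent, the expectation for compound 4 in this assay is a step of about a 1.1-fold lower number from compound 3 to compound 4 (0.05 log units; within the scatter), which is not beyond the scatter. Compound 4 is therefore estimated at 80000 nM, with a range from 25000 nM to 250000 nM.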

Compound 4, half-maximal inhibitory concentration: 250000 nM
Compound 4: middle estimate off by 3.1-fold (0.49 log units), on the low side; the measured number falls inside the stated range.
By their numbers in this assay, from the lowest: compound 1; then compound 3; then compounds 2 and 4 (each within the scatter of the next).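

In this assay, this place on the six-membered aromatic ring of carbon only now has a step of its own: bromo in place of methoxy gives a 2.8-fold higher number from compound 3 to compound 4 (0.44 log units; beyond the scatter) with the rest of the molecule unchanged. The 4-bromophenyl and 3-methylphenyl groups cannot be told apart, with a 1.0-fold higher number from compound 2 to compound 4 (0.01 log units; within the scatter) on record, so among the three aryl groups shown on the aromatic nitrogen only the 4-methoxyphenyl of compound 3 stands apart, with the lower number. No measurement at hand offers a reason for this step.

Going by these compounds, whether an amine, a carboxylic acid or a longer alkoxy chain at this place would read like methoxy or like bromo remains open. So does whether the chloro step on the shared core holds with 4-bromophenyl on the nitrogen.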